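Benzyloxy in place of 5-cyanopyridin-2-yl: stability outlook

This account rests on a few compounds, and the source may have more. Where it says the series, first, only, none or still open, it means among the compounds named here.

In an ADME assay on microsomes from liver (Homo sapiens) for metabolic stability (on this read-out higher numbers stand for a longer-lived compound and lower numbers for a shorter-lived compound), compound 1 (`COc1cc(OCc2cccc(-c3ccc(C#N)cn3)c2)c2cc(-c3cn4nc(OC)sc4n3)oc2c1`) gives 1.57 h. Compound 2 (`COc1cc(OCc2csc(-c3ccc(C(C)(C)O)cc3)n2)c2cc(-c3cn4nc(OC)sc4n3)oc2c1`) gives 1.83 h, and compound 3 (`COc1cc(OCc2csc(-c3ccc(C(N)=O)cc3)n2)c2cc(-c3cn4nc(OC)sc4n3)oc2c1`) gives 1.38 h. All three values lie within the scatter of one another, so compound 1 is not separated from either neighbour.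

Compound 4 (`COc1cc(OCc2cccc(OCc3ccccc3)c2)c2cc(-c3cn4nc(OC)sc4n3)oc2c1`) keeps the core of compound 1 and differs from it in one place: benzyloxy in place of 5-cyanopyridin-2-yl on an aromatic carbon. It is still unmeasured.

For the measured compounds named here, only one measured step is available as a guide: a 1.3-fold lower number from compound 2 to compound 3 (0.12 log units; within the scatter), with carbamoyl in place of 1-hydroxy-1-methylethyl. That step bears only indirectly, since neither benzyloxy nor 5-cyanopyridin-2-yl takes part in it. Going by the values given here, no measured pair covers the present exchange. Compounds 1, 2 and 3 carry different groups on the shared core, yet their values stay within the scatter, and this is the main support for a modest expectation.

No step beyond the scatter is therefore expected in this assay, and no direction is favoured. The expected size of the change is a 1.0-fold lower number from compound 1 to compound 4 (0.02 log units; within the scatter). As far as these compounds go, the range is kept wide, as the exchange itself is untested. For compound 4 the estimate is 1.5 h, with an expected range of 0.7 h to 2.8 h.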

Compound 4, half-life: 1.43 h
The estimate for compound 4 lay 1.0-fold (0.02 log units) above the measured number; the range from low to high includes it.
By their numbers in this assay, from the lowest: compounds 3, 4, 1 and 2 (each within the scatter of the next).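

In this assay, for the compounds shown here, a 1.1-fold lower number from compound 1 to compound 4 (0.04 log units; within the scatter) is the first measured step at this position, on an aromatic carbon of a six-membered aromatic ring of carbon only, meta to a large group. It shows that the nitrile-bearing 5-cyanopyridin-2-yl, with its ring hetero atom and triple bond, can give way to benzyloxy, with the same count of heavy atoms and no net charge on either group, and the read-out stays within the scatter, so this single exchange offers no handle on the half-life. Nothing in hand accounts for the result or links it to any feature of either group.

As far as these compounds go, both groups at this position are uncharged and of equal heavy-atom count, so it remains open whether a carboxylic acid, a primary amine or a single fluorine atom on the same carbon would also stay within the scatter. Also open, from the compounds shown here alone, is whether benzyloxy in place of an aryl group would give a similarly small step on the other side chains carried by compound 2 and compound 3.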